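The compounds below may be only part of what the source reports. "The series", "measured", "known", "first", "only" and "open" are said of these compounds alone.

Two members of this series have been measured. Compound 1 `Cc1nn(C)c(Oc2ccccc2)c1/C=N/OCc1ccc([N+](=O)[O-])cc1` gives 24% in a functional assay on MCF7 cells (Homo sapiens) for antiproliferative activity, tested at 1 uM (a higher number here means more inhibition at the concentration tested (going by the name of the read-out), a lower number less inhibition), and compound 2 `COC(=O)c1ccc(CO/N=C/c2c(C)nn(C)c2Oc2ccc(Cl)cc2)cc1` gives 33.6% in this assay; the two values lie within the scatter of one another, so neither can be set apart from the other. Compound 3 `Cc1ccc(CO/N=C/c2c(C)nn(C)c2Oc2ccccc2)cc1` remains to be measured. It differs from compound 1 by methyl in place of nitro on an aromatic carbon. Among the compounds with values here, no measured pair shows this change, so the step from compound 1 to compound 3 is expected to stay within the scatter, estimated as a number 1 percentage points higher from compound 1 to compound 3 (within the scatter). Compound 3 is therefore expected to give about 25% in this assay, estimated between 10% and 40%.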

Compound 3, a percentage reported as inhibition, at one concentration (the size of the read-out at that concentration, not a potency): 38.2%
Compound 3: middle estimate off by 13.2 percentage points, on the low side, within the range that was stated.
By their numbers in this assay, from the lowest: compounds 1, 2 and 3 (each within the scatter of the next, the first and the last beyond it).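

At this place, on an aromatic carbon para to a large group, methyl in place of nitro gives a number 14.2 percentage points higher from compound 1 to compound 3 (beyond the scatter) in this assay. Within the data shown here, this is the first single change, and it shows that the inhibition read here responds to the group at this place, which compounds 1 and 2, differing in more than one place, could not show. Nothing measured here gives a reason for this step. As far as these compounds go, whether the step belongs to methyl itself or to the loss of nitro stays open. So does what an amine or a carboxylic acid would give at this place.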